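From dimethylamino to pyrrolidin-1-yl on a shared core

This account rests on a few compounds, and the source may have more. Where it says the series, first, only, none or still open, it means among the compounds named here.

- compound 1 `CCN(CC)CC(=O)OC1CC2(N(C)C)CC(c3ccccc3)C1C(c1ccccc1)C2`: 30100 nM
- compound 2 `CN1CCN(CCC(=O)NC2CC3(N(C)C)CC(c4ccccc4)C2C(c2ccccc2)C3)CC1`: 95000 nM
- compound 3 `CN1CCN(CC(=O)N2CCC3(N4CCCCC4)CC(c4ccccc4)C2C(c2ccccc2)C3)CC1`: 177000 nM

All three compounds were tested in an ADME assay on L6 cells (Rattus norvegicus) for cytotoxicity, read by resazurin assay, with a stated time of 72 h; on this read-out higher numbers stand for weaker inhibition and lower numbers for stronger inhibition. Compound 1 stands lowest of the three at 30100 nM, and the numbers for compound 2 and compound 3 both lie higher, beyond the scatter.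

Compound 4 `CCN(CC)CC(=O)OC1CC2(N3CCCC3)CC(c3ccccc3)C1C(c1ccccc1)C2` has yet to be measured. It differs from compound 1 at one place, with pyrrolidin-1-yl in place of dimethylamino on a saturated ring carbon.

Going by the values given here, no pair of measured compounds differs in only one place, so the data offer no direct guide to the size of this step. No move beyond the scatter is expected, with only a slight lean towards a lower number. The estimate is a 1.4-fold lower number from compound 1 to compound 4 (0.14 log units; within the scatter). For compound 4 the estimated value is 22000 nM, with an expected range of 9000 nM to 55000 nM.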

Compound 4, half-maximal inhibitory concentration: 49000 nM
The estimate for compound 4 lay 2.2-fold (0.35 log units) below the measured number, and the stated range covers the measured number.
By their numbers in this assay, from the lowest: compounds 1, 4, 2 and 3 (each within the scatter of the next, the first and the last beyond it).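

Going by these compounds alone, the step gives the first direct reading at this saturated ring carbon: in this assay, pyrrolidin-1-yl in place of dimethylamino gives a 1.6-fold higher number from compound 1 to compound 4 (0.21 log units; within the scatter), with the (((diethylamino)methyl)carbonyl)oxy group and both phenyl groups unchanged. The open dimethylamino group can therefore give way to a five-membered non-aromatic ring here without a move beyond the scatter on this read-out. The data shown offer nothing that would explain the size of this step.

The compounds shown leave open whether a ring such as azetidin-1-yl or morpholin-4-yl on the same carbon would also stay within the scatter of compound 1. They also leave open whether this exchange would give a step of similar size if an acetate group replaced the (((diethylamino)methyl)carbonyl)oxy group.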